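This account rests on a few compounds, and the source may have more. Where it says the series, first, only, none or still open, it means among the compounds named here.

Measured so far in an assay on isolated protein for binding affinity to corticotropin-releasing factor receptor 1 (Homo sapiens); on this read-out lower numbers stand for stronger inhibition and higher numbers for weaker inhibition:
compound 1 `CCCN(CC1CC1)c1cc(C)nc2c(-c3ncc(Cl)cc3Cl)c(C)nn12` gives 3.9 nM
compound 2 `CCCN(CCC)c1cc(C)nc2c(-c3ncc(N=O)cc3C)c(C)nn12` gives 100 nM

Compound 2 gives the higher of the two numbers in this assay, and its gap to compound 1 lies beyond the scatter; nothing more than this pair is known.

Compound 3 `CCCN(CCC)c1cc(C)nc2c(-c3ncc(C)cc3N=O)c(C)nn12` differs from compound 2 by a group of 9 heavy atoms (6 carbon, 2 nitrogen, 1 oxygen; one six-membered aromatic ring with 1 hetero atom) in place of a group of 9 heavy atoms (6 carbon, 2 nitrogen, 1 oxygen; one six-membered aromatic ring with 1 hetero atom), on an aromatic carbon. Within the data shown here, no measured step of this kind exists, so the size of the expected change can only be guessed: for compound 3 an estimate of no change at the digits printed from compound 2 to compound 3 (within the scatter) is assumed, no step beyond the scatter in either direction. Compound 3 is thus expected to give about 100 nM, within a range of 30 nM to 400 nM.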

Compound 3, inhibition constant: > 10000 nM
Compound 3: no number, only a limit; the forecaster's own chance of this, stated with the estimate: 5%; at least 100-fold (2.00 log units) between middle value and limit.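

Compound 3 gives > 10000 nM in this assay, which is a limit of the assay and not a number. Compounds 2 and 3 hold the same atoms, with the methyl and nitroso groups exchanged on the six-membered aromatic ring, and this exchange alone produces an at least 100-fold higher number from compound 2 to compound 3 (2.00 log units; beyond the scatter). The series is therefore highly sensitive to how this ring is substituted, not only to which atoms it carries, which the earlier pair could not show.

Which of the two exchanged groups accounts for the step stays open. Also open, going by these compounds, is what an amine or a methoxy group would give on this ring.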